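Notes on the anilide series: chloro to trifluoromethyl

The source may hold more compounds than are shown below. What is called first, only, known or untested is meant among the compounds shown, and "the series" means these compounds.

Measured so far in a physicochemical assay for lipophilicity, using the shake flask method, in phosphate buffer, measured as octanol-water partition, at pH 7.4; on this read-out lower numbers stand for lower lipophilicity and higher numbers for higher lipophilicity:
compound 1 `COc1cc(-c2cc(C(=O)O)c3ccccc3n2)ccc1OCC(=O)Nc1ccccc1C`: 0.8
compound 2 `COc1cc(-c2cc(C(=O)O)c3ccccc3n2)ccc1OCC(=O)Nc1ccc(C)cc1`: 1.2
compound 3 `COc1cc(-c2cc(C(=O)O)c3ccccc3n2)ccc1OCC(=O)Nc1ccccc1Cl`: 1.6

Compound 3 stands highest of the three measured numbers in this assay. Its nearest neighbour is compound 2, reached by a number 0.40 log units higher from compound 2 to compound 3 (beyond the scatter); the furthest is compound 1, reached by a number 0.80 log units higher from compound 1 to compound 3 (beyond the scatter). The remaining measured step, a number 0.40 log units higher from compound 1 to compound 2 (beyond the scatter), is of the same modest size as the step into compound 3 from compound 2.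

Compound 4 `COc1cc(-c2cc(C(=O)O)c3ccccc3n2)ccc1OCC(=O)Nc1ccccc1C(F)(F)F` is not yet measured. The change from compound 3 is trifluoromethyl in place of chloro on an aromatic carbon. Among the measured compounds shown here, no measured step swaps chloro for trifluoromethyl, so the nearest guide is the step into compound 3 from compound 1, in which chloro replaced methyl at the same place and the number rose modestly. On that basis a further modest rise beyond the scatter is expected, though the direction is better supported than the size. The estimated step is a number 0.30 log units higher from compound 3 to compound 4 (within the scatter). Compound 4 is therefore expected to give about 1.9 in this assay, within a range from 1.4 to 2.4.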

Compound 4, distribution coefficient: 1.3
Compound 4: middle estimate off by 0.60 log units, on the high side; the measured number lies below the stated range.
By their numbers in this assay, from the lowest: compound 1; then compounds 2, 4 and 3 (each within the scatter of the next, the first and the last beyond it).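

At this aromatic carbon, ortho to a large group, trifluoromethyl in place of chloro gives a number 0.30 log units lower from compound 3 to compound 4 (within the scatter) in this assay and so does not separate the two groups, although chloro in place of methyl did separate. Against methyl, trifluoromethyl still gives a number 0.50 log units higher from compound 1 to compound 4 (beyond the scatter) and thus joins chloro on the same side of methyl for this pair of comparisons, making methyl the only one of the three groups that stands apart at this carbon. Compound 4 also gives a number 0.10 log units higher from compound 2 to compound 4 (within the scatter) and cannot be told apart from the compound carrying 4-methylphenyl on the amide-type nitrogen.

No available data account for these results. As far as these compounds go, whether an amine or a longer alkyl chain at this carbon would fall with methyl or with chloro and trifluoromethyl remains open.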